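The source may hold more compounds than are shown below. What is called first, only, known or untested is meant among the compounds shown, and "the series" means these compounds.

Three compounds share a core carrying two hydroxyl groups and a nitro group, and all have been tested in an assay on isolated protein for inhibition of Amine oxidase [flavin-containing] B (Homo sapiens), read by fluorescence; on this read-out lower numbers stand for stronger inhibition and higher numbers for weaker inhibition. Compound 1 `O=C(/C=C/c1cccs1)c1cc(O)c(O)c([N+](=O)[O-])c1` gives 62900 nM. Compound 2 `O=C(/C=C/c1cccc(O)c1)c1cc(O)c(O)c([N+](=O)[O-])c1` gives 55800 nM, and the single-point change between them is a 1.1-fold lower number from compound 1 to compound 2 (0.05 log units; within the scatter). Compound 3 `CC(=O)N1N=C(c2cc(O)c(O)c([N+](=O)[O-])c2)CC1c1nccs1` gives 68200 nM; its number is the highest of the three, but its gaps to compound 1 and to compound 2 both lie within the usual scatter, so no order among the three can be read from these figures.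

Compound 4 `CC(=O)N1N=C(c2cc(O)c(O)c([N+](=O)[O-])c2)CC1c1ccoc1` differs from compound 3 in one place: furan-3-yl in place of 1,3-thiazol-2-yl on a saturated ring carbon. Among the compounds with values here, no measured step exchanges one five-membered aromatic ring for another on the saturated ring carbon, so there is no direct precedent. Within the data shown here, the one step that is known, the exchange of a five-membered heteroaromatic ring for a hydroxyphenyl ring on the chain of compound 1 to give compound 2, stayed within the scatter. On that basis the expected step in this assay is a 1.0-fold lower number from compound 3 to compound 4 (0.02 log units; within the scatter), with no change beyond the scatter. Compound 4 is therefore expected to give about 65000 nM, within a range from 30000 nM to 140000 nM.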

Compound 4, half-maximal inhibitory concentration: 126000 nM
Compound 4: the middle estimate sits 1.9-fold (0.29 log units) below what was measured; measured number inside the range.
By their numbers in this assay, from the lowest: compounds 2, 1, 3 and 4 (each within the scatter of the next, the first and the last beyond it).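

In this assay, within the data shown here, this is the first measured change on the saturated ring carbon, and a 1.8-fold higher number from compound 3 to compound 4 (0.27 log units; within the scatter) stays within the usual scatter. The ring on this carbon can therefore go from 1,3-thiazol-2-yl, with two hetero atoms and two hydrogen-bond acceptors, to furan-3-yl, with one of each, without a difference that these figures can separate from repeat-to-repeat variation. Nothing available here bears on how the ring exchange acts on this result.

Going by these compounds, with only these two rings compared at this position, the effect of a quite different group there, such as a carboxylic acid or an amine, remains open. It is also unknown whether replacing the acetyl group on the neighbouring ring atom would shift the number more clearly.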